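The source may hold more compounds than are shown below. What is called first, only, known or untested is meant among the compounds shown, and "the series" means these compounds.

Working notes on the adenosine receptor series.

Two compounds carry measured values. Compound 1 `Nc1nc(NCc2cccs2)nc2sc(-c3ccco3)nc12` gives 6.43 nM in an assay on CHO cells for displacement of a labelled ligand from adenosine receptor A3 (Homo sapiens), read by scintillation counting, with a stated time of 120 min; a lower number here means a stronger inhibitor, a higher number a weaker inhibitor. Compound 2 `COc1cccc(CNc2nc(N)c3nc(-c4ccc(C)o4)sc3n2)c1` gives 160 nM in this assay, and this is the highest of the two numbers shown, the nearest being compound 1 with a number lower by a margin well beyond the usual scatter.

The next compound, compound 3 `Cc1ccc(-c2nc3c(N)nc(NCc4cccs4)nc3s2)o1`, is compound 2 with one change: thiophen-2-yl in place of 3-methoxyphenyl on a saturated chain carbon bound to a nitrogen on an aromatic ring. The thiophen-2-yl group that enters is the same group that compound 1 carries on a saturated chain carbon bound to a nitrogen on an aromatic ring, and compound 1 gives 6.43 nM in this assay. Compound 2, with 3-methoxyphenyl in that place, gives 160 nM. Going by the values given here, no directly measured step connects compound 2 and compound 3, so the expectation rests on those two values only. A drop in the inhibition constant, well beyond the scatter, is expected, amounting to a 16-fold lower number from compound 2 to compound 3 (1.20 log units; beyond the scatter).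

For compound 3 the estimate in this assay is 10 nM, with a range from 3 nM to 35 nM, the number expected to land close to that of compound 1.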

Compound 3, inhibition constant: 15.3 nM
Estimate against measurement, compound 3: 1.5-fold (0.18 log units) below; the range from low to high includes it.
By their numbers in this assay, from the lowest: compound 1; then compound 3; then compound 2.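

Working notes, continued. In this assay, a 10-fold lower number from compound 2 to compound 3 (1.02 log units; beyond the scatter), so thiophen-2-yl in place of 3-methoxyphenyl on a saturated chain carbon bound to a nitrogen on an aromatic ring is now a large change read directly in one place, with no second difference in the pair. The second reading, a 2.4-fold higher number from compound 1 to compound 3 (0.38 log units; beyond the scatter), shows that methyl in place of hydrogen on an aromatic carbon is a modest change, yet still beyond the scatter, so this aromatic carbon also affects the number in this assay, though the step there is classed as smaller than the large one at the chain carbon. Nothing at hand bears on the reason for either step.

The compounds shown leave open whether methyl in place of hydrogen on the aromatic carbon gives a step of the same size when 3-methoxyphenyl, rather than thiophen-2-yl, sits on the saturated chain carbon. They also leave open how an unsubstituted phenyl, a cyclohexyl group or a longer chain would read at that chain carbon, and how an ethyl group or a chlorine atom would read in place of the methyl.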